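Swapping the Hydroxypropyl Chain for a Trifluoromethylphenyl Group

The source may hold more compounds than are shown below. What is called first, only, known or untested is meant among the compounds shown, and "the series" means these compounds.

Of the compounds shown here, three sharing one core have been measured in an ADME assay on SK-OV-3 cells (Homo sapiens) for cytotoxicity, read by sulforhodamine B assay, with a stated time of 48 h, tested at 10 uM; a lower number here means less inhibition, a higher number more inhibition at the concentration tested (going by the name of the read-out). Compound 1 `COc1nc2ccc(Br)cc2cc1C(c1ccccc1)n1cc(-c2ccccc2)nn1` gives 13.7%, compound 2 `COc1nc2ccc(Br)cc2cc1C(c1ccccc1)n1cc(-c2ccccc2F)nn1` gives 7.33%, and compound 3 `COc1nc2ccc(Br)cc2cc1C(c1ccccc1)n1cc(CCCO)nn1` gives 13.8%. Compound 3 therefore sits together with compound 1, and its gap to compound 2 is also within the scatter, so none of the three can be set apart from the others on these numbers.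

Compound 4 `COc1nc2ccc(Br)cc2cc1C(c1ccccc1)n1cc(-c2ccccc2C(F)(F)F)nn1` differs from compound 3 in one place: 2-(trifluoromethyl)phenyl in place of 3-hydroxypropyl on an aromatic carbon. For the measured compounds named here, two measured steps bear on this change, since both exchange an aryl group for the 3-hydroxypropyl chain or the reverse: a number 0.1 percentage points higher from compound 1 to compound 3 (within the scatter) and a number 6.5 percentage points higher from compound 2 to compound 3 (within the scatter). A third step varies the substituent on the aryl group itself: a number 6.4 percentage points lower from compound 1 to compound 2 (within the scatter). All three stayed within the scatter, which gives no ground to expect the 2-(trifluoromethyl)phenyl group to move the number beyond it either.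

For compound 4 the expected step is a number 2.8 percentage points lower from compound 3 to compound 4 (within the scatter), that is, no change beyond the scatter. Compound 4 is thus estimated at 11% in this assay, with a range from 0% to 24%.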

Compound 4, a percentage reported as inhibition, at one concentration (the size of the read-out at that concentration, not a potency): 9.55%
Beside the measured number, compound 4's estimate is 1.5 percentage points above it, within the range that was stated.
By their numbers in this assay, from the lowest: compounds 2, 4, 1 and 3 (each within the scatter of the next).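

Exchanging the 3-hydroxypropyl chain, which has a hydrogen-bond donor and a hydrogen-bond acceptor, for the 2-(trifluoromethyl)phenyl group, which has neither, gives a number 4.3 percentage points lower from compound 3 to compound 4 (within the scatter) in this assay. This aromatic carbon therefore carries a group of 10 heavy atoms with one six-membered aromatic ring, and the number stays as close to that of the 4-heavy-atom chain as the earlier aryl groups did. On the phenyl ring itself, the comparison now extends to a third substituent: trifluoromethyl in place of fluoro gives a number 2.2 percentage points higher from compound 2 to compound 4 (within the scatter) and trifluoromethyl in place of hydrogen gives a number 4.2 percentage points lower from compound 1 to compound 4 (within the scatter), so none of the three separates from the others, and no measurement on these groups is available to explain this result.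

All four compounds were read at a single concentration, so these numbers leave open how they compare at any other concentration. It also remains open whether an amine, a carboxylic acid or a longer chain on this aromatic carbon would move the number beyond the scatter, as none of the groups shown has done.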